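Methoxy on the Sulfonate Aryl Ring: Expected Effect in MCF7

This account rests on a few compounds, and the source may have more. Where it says the series, first, only, none or still open, it means among the compounds named here.

Compounds measured so far:
compound 1 `COc1ccccc1OS(=O)(=O)c1ccc(N2CCN(C)C2=O)cc1`, 26000 nM;
compound 2 `CCN1CCN(c2ccc(S(=O)(=O)Oc3ccccc3OC)cc2)C1=O`, > 100000 nM;
compound 3 `CCCCN1CCN(c2ccc(S(=O)(=O)Oc3ccccc3)cc2)C1=O`, 8800 nM.

In a functional assay on MCF7 cells (Homo sapiens) for antiproliferative activity, read by sulforhodamine B assay, with a stated time of 48 h (a higher number here means a weaker inhibitor, a lower number a stronger inhibitor), compound 3 gives the lowest of the two numbers reported, and its nearest neighbour, compound 1, gives 26000 nM. Compound 2 does not give a number in this assay but only a limit, > 100000 nM. Among the compounds with values here, the one step measured here, an at least 3.8-fold higher number from compound 1 to compound 2 (0.58 log units; beyond the scatter), concerns the chain on the ring nitrogen and rests on the limit (the limit of > 100000 nM in this assay, at which 1 of the 3 values shown sits).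

Compound 4 `CCCCN1CCN(c2ccc(S(=O)(=O)Oc3ccccc3OC)cc2)C1=O` differs from compound 3 by methoxy in place of hydrogen on an aromatic carbon. Within the data shown here, no measured step covers the entry or removal of this methoxy: compounds 1 and 2 both carry it and compound 3 lacks it, and the pairs that differ only in that way are not among those measured. So nothing here points to a direction, and the account therefore expects a step of no clear size in this assay, a 1.7-fold higher number from compound 3 to compound 4 (0.23 log units; within the scatter). Compound 4 is accordingly estimated at 15000 nM, between 5000 nM and 60000 nM.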

Compound 4, half-maximal inhibitory concentration: 3800 nM
Estimate against measurement, compound 4: 3.9-fold (0.60 log units) above; measured number below the stated range.
By their numbers in this assay, from the lowest: compound 4; then compound 3; then compound 1. At a limit, above all of these: compound 2.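

In this assay, within the data shown here, the methoxy, ortho to a large group on the sulfonate aryl ring, now has a measured step of its own, a 2.3-fold lower number from compound 3 to compound 4 (0.36 log units; beyond the scatter), though this one pair is its only evidence. With the methoxy held in place, the chain on the ring nitrogen also proves to matter, with a 6.8-fold lower number from compound 1 to compound 4 (0.84 log units; beyond the scatter) and an at least 26-fold lower number from compound 2 to compound 4 (1.42 log units; beyond the scatter), so the number does not fall steadily as the chain lengthens, and compound 2 goes against any such trend. The larger of these steps rests on a limit, not a number: the limit of > 100000 nM in this assay, at which 1 of the 4 values shown sits.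

The compounds shown leave open whether the methoxy step would hold with the methyl or ethyl chain. They also leave open whether a longer chain on the ring nitrogen, or an amine or hydroxyl in place of the methoxy, would lower the number further.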